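This account rests on a few compounds, and the source may have more. Where it says the series, first, only, none or still open, it means among the compounds named here.

Measured so far: compound 1 `CCCn1c(-c2ccco2)nc2c(N)ncnc21` with 790 nM in an assay on CHO cells for displacement of a labelled ligand from transmembrane domain-containing protein TMIGD3 (Homo sapiens); a lower number here means a stronger inhibitor, a higher number a weaker inhibitor; compound 2 `CCCn1c(-c2ccco2)nc2c(N)nc(NCc3ccccc3)nc21` with 29 nM; compound 3 `CCCn1c(Br)nc2c(NCCCc3ccccc3)ncnc21` with 12200 nM.

In this assay compound 1 sits second highest of the three numbers, closest to compound 3 and far from compound 2. Compound 4 `CCCn1c(-c2ccco2)nc2c(NCc3ccccc3)ncnc21` differs from compound 1 by benzyl in place of hydrogen on a nitrogen on an aromatic ring. Among the compounds with values here, no measured step matches this change. Within the data shown here, the only step known, a 27-fold lower number from compound 1 to compound 2 (1.44 log units; beyond the scatter), puts a benzylamino on an aromatic carbon, a different place, so it cannot be carried over. Compound 3, which carries a phenylpropyl on the same kind of nitrogen but also a bromo in place of the furanyl, gives the highest number of the set. With the change at this nitrogen unsupported, compound 4 is expected to give a weaker number, a step of a 3.2-fold higher number from compound 1 to compound 4 (0.50 log units; beyond the scatter). Compound 4 is estimated at 2500 nM, within 500 nM to 12000 nM.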

Compound 4, inhibition constant: 402 nM
Compound 4: middle estimate off by 6.2-fold (0.79 log units), on the high side, outside the stated range (below it).
By their numbers in this assay, from the lowest: compound 2; then compounds 4 and 1 (each within the scatter of the next); then compound 3.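

In this assay, benzyl in place of hydrogen on a nitrogen on an aromatic ring gives a 2.0-fold lower number from compound 1 to compound 4 (0.29 log units; within the scatter) and so leaves the number indistinguishable from that of compound 1. This nitrogen therefore carries the added benzyl, with its six-membered aromatic ring, without a change that can be told from the scatter. Nothing available explains this result.

Open, on these data alone, is whether a longer chain such as phenylethyl on this nitrogen, or a carboxylic acid on the benzyl ring, would move the number beyond the scatter.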